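This account rests on a few compounds, and the source may have more. Where it says the series, first, only, none or still open, it means among the compounds named here.

Measured so far in a functional assay on MCF cells (Homo sapiens) for antiproliferative activity, with a stated time of 72 h; a higher number here means a weaker inhibitor, a lower number a stronger inhibitor:
compound 1 `OC[C@H]1O[C@@H](n2cnc3c(NCc4cccc(Br)c4)ncnc32)[C@H](O)[C@@H]1O` gives > 166000 nM as a limit
compound 2 `Cc1cccc(CNc2ncnc3c2ncn3[C@@H]2O[C@H](CO)[C@@H](O)[C@H]2O)c1` gives > 166000 nM as a limit

Compound 2 has no number in this assay, only the limit > 166000 nM as its reading. Going by the values given here, the one other value is a limit as well, so the evidence amounts to the limit of > 166000 nM in this assay, at which 2 of the 2 values shown sit, and nothing finer.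

Compound 3 `Cc1ccc(CNc2ncnc3c2ncn3[C@@H]2O[C@H](CO)[C@@H](O)[C@H]2O)cc1` carries 4-methylphenyl in place of 3-methylphenyl on a saturated chain carbon bound to a nitrogen on an aromatic ring. Among the compounds with values here, the only measured step that bears on this change is a step that the two limits leave unreadable from compound 1 to compound 2 and it gives neither a size nor a direction. Since compound 2 offers only > 166000 nM as a reference, nothing measured points to a change, and no step beyond the scatter is expected in this assay for this shift of the methyl group. The estimated step is a number no higher from compound 2 to compound 3 (the limit leaves the size open) on this reading. For compound 3 the estimate is 166000 nM with an expected range from 90000 nM to 250000 nM and a report of only a limit is the likeliest outcome.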

Compound 3, half-maximal inhibitory concentration: > 166000 nM
Compound 3: no number, only a limit; the forecaster's own chance of this, stated with the estimate: 85%; the middle value lies on the limit itself.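

In this assay compound 3 gives > 166000 nM, which is a limit and not a number. Going by these compounds alone, compound 1 and compound 2 also carry only limits, so no step among the three can be read. The compounds shown leave open how strongly any of them inhibits, and whether exchanging 3-methylphenyl, 4-methylphenyl and 3-bromophenyl changes that at all.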